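The source may report more compounds than this note shows. Statements on the series, on what has been measured and on what is new or still open speak of the compounds shown alone.

The compounds measured in a functional assay (aorta) with Rattus norvegicus as the target (a lower number here means that less compound is needed, a higher number that more compound is needed for the effect), are: compound 1 `CCC(C)NC1=NS(=O)(=O)c2cc(F)ccc2N1`, which gives 39.2 uM; compound 2 `O=S1(=O)NC(NCC2CC2)=Nc2ccc(F)cc21`, which gives 146 uM; and compound 3 `CCC(C)NC1=NS(=O)(=O)c2cc(Cl)ccc2N1`, which gives 15.5 uM.

Among these three, compound 2 gives the highest number, and its separation from both compound 1 and compound 3 lies beyond the scatter. The difference between the core of compound 2 and the core of compound 1 is not broken down here. Compound 1 and compound 3 differ in a single place, (chloro in place of fluoro on an aromatic carbon). In this assay that change produced a 2.5-fold lower number from compound 1 to compound 3 (0.40 log units; beyond the scatter), a modest step that nevertheless lies beyond the scatter. Compound 4 `O=S1(=O)NC(NCC2CC2)=Nc2ccc(Cl)cc21`, which has not yet been measured, carries the same change relative to compound 2, (chloro in place of fluoro on an aromatic carbon), at the same kind of position on the same kind of ring. Because the step of a 2.5-fold lower number from compound 1 to compound 3 (0.40 log units; beyond the scatter) lies beyond the scatter, a step of similar size is expected here: a 2.5-fold lower number from compound 2 to compound 4 (0.40 log units; beyond the scatter). Compound 4 is therefore estimated at 58 uM, with a likely range from 30 uM to 110 uM.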

Compound 4, concentration for half-maximal effect: 41.2 uM
Estimate against measurement, compound 4: 1.4-fold (0.15 log units) above; low and high end bracket the measured number.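

In this assay chloro in place of fluoro on an aromatic carbon gave a 3.5-fold lower number from compound 2 to compound 4 (0.55 log units; beyond the scatter). Set beside the earlier step, the two results agree in direction and do not differ in size beyond what repeated measurements would allow: the same change on two cores in this assay, a 2.5-fold lower number (0.40 log units; beyond the scatter) from compound 1 to compound 3 and a 3.5-fold lower number (0.55 log units; beyond the scatter) from compound 2 to compound 4, 1.4-fold (0.15 log units) apart, within the scatter of two such steps. The change therefore carried from one core to the other in this small series, but two pairs show only that it did so here, not that it would do so on a different core, and they do not explain why the number falls.

The compounds shown leave open how bromo, methyl or a nitrile on that same aromatic carbon would compare with chloro and fluoro. They also leave open whether the step would persist with a longer chain or a carboxylic acid in place of the side chains shown.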